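Tryptamine piperidine series: swapping the piperidine substituent

The source may report more compounds than this note shows. Statements on the series, on what has been measured and on what is new or still open speak of the compounds shown alone.

Working notes on three measured compounds and one untested analogue. In an assay on CHO cells for agonist activity at 5-hydroxytryptamine receptor 1D (Homo sapiens), read by GTPgammaS binding (a lower number here means that less compound is needed, a higher number that more compound is needed for the effect), compound 1 `O=S(=O)(NCC1CCN(CCCc2c[nH]c3ccc(-n4cnnc4)cc23)CC1)c1ccccc1` gives 12 nM. Compound 2 `c1ccc(C2CCCCN2C2CCN(CCCc3c[nH]c4ccc(-n5cnnc5)cc34)CC2)cc1` gives 4.7 nM in this assay, and compound 3 `OC[C@H](NC1CCN(CCCc2c[nH]c3ccc(Cn4cncn4)cc23)CC1)c1ccccc1` gives 32 nM there. Compound 1 thus stands second highest of the three numbers; its gap to compound 2 lies beyond the scatter, as does its gap to compound 3, so the three values are distinct at the level of this assay.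

The next compound, compound 4 `CC(C)=CCN(C)C1CCN(CCCc2c[nH]c3ccc(-n4cnnc4)cc23)CC1`, differs from compound 1 in one place: methyl(3-methylbut-2-en-1-yl)amino in place of ((phenylsulfonyl)amino)methyl on a saturated ring carbon. Going by the values given here, no pair of measured compounds differs in exactly one place, so no measured step guides this change directly. What the three values show is that rather different groups on the saturated ring carbon of the shared core keep the numbers within a modest band, from compound 2 to compound 3.

The step of a 1.7-fold higher number from compound 1 to compound 4 (0.22 log units; within the scatter) is therefore expected to be small, in either direction, and plausibly not beyond the scatter. The estimate for compound 4 in this assay is 20 nM, with a range from 6 nM to 70 nM.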

Compound 4, half-maximal effective concentration: 1.8 nM
Compound 4: middle estimate off by 11-fold (1.05 log units), on the high side, outside the stated range (below it).
By their numbers in this assay, from the lowest: compound 4; then compound 2; then compound 1; then compound 3.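

Read in this assay, methyl(3-methylbut-2-en-1-yl)amino in place of ((phenylsulfonyl)amino)methyl gives a 6.7-fold lower number from compound 1 to compound 4 (0.82 log units; beyond the scatter), the first single-place step in the series and the first direct sign that the number responds to the group on this saturated ring carbon. The lower number comes with a smaller group, with fewer heavy atoms, no ring and 0 hydrogen-bond donors, so for this pair neither the six-membered aromatic ring of carbon only nor the hydrogen-bond donor of the leaving group is needed for a low number. No measured evidence bears on the reason for this step, and this one pair cannot separate the loss of the ring, the loss of the donor and the change in size.

Which part of the entering group goes with the lower number remains open, including whether its double bond matters. A saturated 3-methylbutyl chain on the same nitrogen, or a plain dimethylamino group on the same ring carbon, would test this directly, and the direction of either step cannot be told from the compounds shown.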